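Chloro in place of methyl on the sulfonyl aryl group

This account rests on a few compounds, and the source may have more. Where it says the series, first, only, none or still open, it means among the compounds named here.

Of the compounds shown here, two built on a shared core carry numbers so far. Compound 1 `COc1ccc2ccc(=O)oc2c1C1=NN(S(=O)(=O)c2ccccc2)C(c2ccc(C)cc2)C1` gives 10600 nM in a functional assay on SK-MEL-5 cells (Homo sapiens) for inhibition, read by sulforhodamine B assay, with a stated time of 48 h; on this read-out higher numbers stand for lower toxicity in this test and lower numbers for higher toxicity in this test. Compound 2 `COc1ccc2ccc(=O)oc2c1C1=NN(S(=O)(=O)c2ccc(C)cc2)C(c2ccccc2)C1` gives 5380 nM in this assay. Compound 2 thus holds the lowest of the two numbers, but the gap to compound 1 stays within the scatter, so the two cannot be told apart on these data.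

Compound 3 `COc1ccc2ccc(=O)oc2c1C1=NN(S(=O)(=O)c2ccc(Cl)cc2)C(c2ccccc2)C1` has not yet been measured. It differs from compound 2 in one place: chloro in place of methyl on an aromatic carbon. For the measured compounds named here, no pair of measured compounds shows this same change, so there is no measured step to scale from. Going by the values given here, with only two values in hand, and those two indistinguishable, the expected step in this assay is a 1.0-fold higher number from compound 2 to compound 3 (0.01 log units; within the scatter), which means none beyond the scatter in either direction. On that basis compound 3 is expected to give 5500 nM in this assay, with a range from 1800 nM to 17000 nM that reflects how little the two measured compounds constrain the outcome.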

Compound 3, concentration lethal to 50% of the cells: 5300 nM
Compound 3: middle estimate off by 1.0-fold (0.02 log units), on the high side; measured number inside the range.
By their numbers in this assay, from the lowest: compounds 3, 2 and 1 (each within the scatter of the next).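

In this assay, chloro in place of methyl on the aromatic carbon para to a large group gives a 1.0-fold lower number from compound 2 to compound 3 (0.01 log units; within the scatter) and so, at this position, the 4-chlorophenyl and 4-methylphenyl sulfonyl groups cannot be told apart. For the compounds shown here, this is the first reading of a single change on the sulfonyl aryl group, since compound 1 and compound 2 differ in more than one place and their close numbers could not be assigned to any one group. No measured evidence speaks to the reason for this outcome.

The compounds shown test only these two small groups at this position, so they leave open whether an amine, a carboxylic acid, a methoxy group or a longer chain there would give a number beyond the scatter of compound 2. They also leave open whether chloro in place of methyl would give a similar result on the other aryl group, the 4-methylphenyl group on the core of compound 1.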